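Benzamide variation on the shared core against HeLa growth

The source may report more compounds than this note shows. Statements on the series, on what has been measured and on what is new or still open speak of the compounds shown alone.

The series shares the core of compound 1 `O=C(Nc1ccc(Cl)c(-c2nnc3c(Cl)cccn23)c1)c1ccc(Cl)cc1` and varies the aryl group on the carbonyl carbon of the amide. In a functional assay on HeLa cells (Homo sapiens) for antiproliferative activity, read by MTT assay, with a stated time of 72 h (a higher number here means a weaker inhibitor, a lower number a stronger inhibitor), compound 1 gives only a limit, > 100000 nM. Compound 2 `Cc1cc(Cl)ccc1C(=O)Nc1ccc(Cl)c(-c2nnc3c(Cl)cccn23)c1` carries a methyl in place of hydrogen on an aromatic carbon. In this assay compound 2 likewise gives only a limit, > 100000 nM. The step from compound 1 to compound 2 reads as a step that the two limits leave unreadable from compound 1 to compound 2; both values sit at the limit of > 100000 nM in this assay, at which 2 of the 2 values shown sit, so compound 2 stands at the limit and nowhere else on the numbers shown. Compound 3 `O=C(Nc1ccc(Cl)c(-c2nnc3c(Cl)cccn23)c1)c1c(F)cccc1Cl` differs from compound 2 by 2-chloro-6-fluorophenyl in place of 4-chloro-2-methylphenyl on a carbonyl carbon. For the measured compounds named here, no measured step bears readably on this change, the only step at hand being unreadable. Compound 3 is expected to give an estimated value of 150000 nM in this assay, and its expected range is estimated to run from 40000 nM to 600000 nM, with a limit again the likeliest outcome. The expected step from compound 2 to compound 3 is a step that the limit leaves unreadable from compound 2 to compound 3, meaning nothing beyond the scatter.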

Compound 3, half-maximal inhibitory concentration: > 100000 nM
Compound 3 gave a limit, no number (the forecaster's own chance of this, stated with the estimate: 75%); the middle value is on the limit's open side.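

No step among compound 1, compound 2 and compound 3 can be read in this assay, as each gives only a limit: the limit of > 100000 nM in this assay, at which 3 of the 3 values shown sit.

From the compounds shown here alone, whether any aryl group on the carbonyl carbon of the shared core gives a number rather than a limit stays open.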